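This account rests on a few compounds, and the source may have more. Where it says the series, first, only, none or still open, it means among the compounds named here.

In an ADME assay on H9 cells (Homo sapiens) for cytotoxicity, read by XTT assay, with a stated time of 6 days (on this read-out higher numbers stand for lower toxicity in this test and lower numbers for higher toxicity in this test), compound 1 `Cc1cc(C)c(Oc2cc(Nc3ccc(C#N)cc3)c(N)cc2[N+](=O)[O-])c(C)c1` gives 32200 nM. Compound 2 `Cc1cc(C)c(Oc2ccc(N)c(Nc3ccc(C#N)cc3)c2)c(C)c1` gives 51000 nM. Hydrogen in place of nitro on an aromatic carbon thus amounts to a 1.6-fold higher number from compound 1 to compound 2 (0.20 log units; within the scatter). For compound 3 `Cc1cc(Br)cc(C)c1Oc1ccc([N+](=O)[O-])c(Nc2ccc(C#N)cc2)c1`, this assay reports only a limit, > 57000 nM. Compound 4 `Cc1cc(C#N)cc(C)c1Oc1cc(Nc2ccc(C#N)cc2)c(N)cc1[N+](=O)[O-]` has cyano in place of methyl on an aromatic carbon, para to a large group. Within the data shown here, no measured step covers this replacement. The nearest evidence is the nitro replacement, which concerns a different group and gave a 1.6-fold higher number from compound 1 to compound 2 (0.20 log units; within the scatter), so no change beyond the scatter is expected in this assay. The expected step is a 1.1-fold lower number from compound 1 to compound 4 (0.03 log units; within the scatter). The estimate for compound 4 is 30000 nM, with an expected range of 13000 nM to 65000 nM.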

Compound 4, half-maximal cytotoxic concentration: 62700 nM
Compound 4: middle estimate off by 2.1-fold (0.32 log units), on the low side, and the stated range covers the measured number.
By their numbers in this assay, from the lowest: compounds 1, 2 and 4 (each within the scatter of the next).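

In this assay, the change from 2,4,6-trimethylphenyl to 4-cyano-2,6-dimethylphenyl gives a 1.9-fold higher number from compound 1 to compound 4 (0.29 log units; within the scatter). This position, para to a large group, thus takes cyano in place of methyl without a shift beyond the scatter, whereas the earlier step concerned only the nitro group. The only limit among the compounds shown belongs to compound 3: the limit of > 57000 nM in this assay, at which 1 of the 4 values shown sits.

On these data alone, whether an amine, a carboxylic acid or a longer chain at this position would move the number beyond the scatter remains open. Also open, as far as these compounds go, is whether cyano here would give the same result in a compound without the nitro group.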